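The source may report more compounds than this note shows. Statements on the series, on what has been measured and on what is new or still open speak of the compounds shown alone.

Measured so far in a functional assay on CaEs17 cells (Homo sapiens) for cytotoxicity, read by MTT assay, with a stated time of 72 h; a lower number here means a stronger inhibitor, a higher number a weaker inhibitor:
- compound 1 `C=C1C(=O)[C@@]23C(=O)OC[C@]4(C(=O)CCC(C)(C)[C@H]4C=O)[C@@H]2CC[C@@H]1[C@H]3OC(C)=O`: 1350 nM
- compound 2 `C=C1C(=O)[C@@]23C(=O)OC[C@]4(C(=O)CCC(C)(C)[C@H]4C=O)[C@@H]2CC[C@@H]1[C@H]3OC(=O)c1ccc([N+](=O)[O-])cc1`: 2680 nM
- compound 3 `C=C1C(=O)[C@@]23C(=O)OC[C@]4(C(=O)CCC(C)(C)[C@H]4C=O)[C@@H]2CC[C@@H]1[C@H]3OC(=O)c1ccccc1F`: 8550 nM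

Compound 3 has the highest number of the three. The steps leading to it are a 6.3-fold higher number from compound 1 to compound 3 (0.80 log units; beyond the scatter) and a 3.2-fold higher number from compound 2 to compound 3 (0.50 log units; beyond the scatter), both modest, whereas the remaining measured step is a 2.0-fold higher number from compound 1 to compound 2 (0.30 log units; within the scatter).

Next in line is compound 4 `C=C1C(=O)[C@@]23C(=O)OC[C@]4(C(=O)CCC(C)(C)[C@H]4C=O)[C@@H]2CC[C@@H]1[C@H]3OC(=O)c1ccccc1Cl`, which carries chloro in place of fluoro on an aromatic carbon, ortho to a large group: chloro in place of fluoro on an aromatic carbon.

Going by the values given here, no measured step swaps one halogen for another. The two steps into compound 3 are the nearest evidence, but each replaces the whole group on the carbonyl carbon, so they bound the likely size only loosely. A smaller change at this one place is expected to give no step beyond the scatter in this assay, and the data give no firm direction. The expected step is a 1.2-fold lower number from compound 3 to compound 4 (0.09 log units; within the scatter). For compound 4 the estimated value is 7000 nM, with an expected range of 3000 nM to 15000 nM.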

Compound 4, half-maximal inhibitory concentration: 2010 nM
Compound 4: middle estimate off by 3.5-fold (0.54 log units), on the high side, outside the stated range (below it).
By their numbers in this assay, from the lowest: compounds 1, 4 and 2 (each within the scatter of the next); then compound 3.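

In this assay, exchanging fluoro for chloro on an aromatic carbon, ortho to a large group, gives a step beyond the scatter (a 4.3-fold lower number from compound 3 to compound 4 (0.63 log units; beyond the scatter)), so a change of one heavy atom at this place is enough to shift the read-out. With 2-chlorophenyl on the carbonyl carbon, the steps to the other two compounds stay within the scatter (a 1.3-fold lower number from compound 2 to compound 4 (0.12 log units; within the scatter); a 1.5-fold higher number from compound 1 to compound 4 (0.17 log units; within the scatter)), which leaves compound 3 as the only one of the four set apart, and shows that an aryl group in place of methyl does not by itself raise the number. Nothing on hand accounts for the difference between fluoro and chloro.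

From the compounds shown here alone, it remains open whether bromo or methoxy at this same place would read like chloro or like fluoro. Also open, going by these compounds, is whether an amide in place of the ester link would preserve the difference between the two halogens.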